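A Sulfur-to-Oxygen Ring Swap Carried to a Second Core

The source may hold more compounds than are shown below. What is called first, only, known or untested is meant among the compounds shown, and "the series" means these compounds.

Compound 1 `COc1ccc(C2=NN(c3ccccc3)C(c3ccc(C)cc3)C2S(=O)(=O)CC2=NCCO2)cc1` and compound 3 `COc1ccc(C2=NN(c3ccccc3)C(c3ccc(C)cc3)C2S(=O)(=O)CC2=NCCS2)cc1` share one core, while compound 2 `O=S(=O)(CC1=NCCS1)C1C(c2ccccc2)=NOC1c1ccccc1` and compound 4 `O=S(=O)(CC1=NCCO1)C1C(c2ccccc2)=NOC1c1ccccc1` share another; the difference between the two cores is not broken down here. In a functional assay, read by Griess assay, with a stated time of 150 min, tested at 50 ug/mL (on this read-out lower numbers stand for a weaker effect and higher numbers for a stronger effect at the one concentration tested), compound 1 gives 59.1% and compound 3 gives 39.4%. Compound 2 is reported in this assay as "not active" (no number reported), without a number. The change from compound 3 to compound 1 is a group of 5 heavy atoms (3 carbon, 1 nitrogen, 1 oxygen; one five-membered non-aromatic ring with 2 hetero atoms) in place of a group of 5 heavy atoms (3 carbon, 1 nitrogen, 1 sulfur; one five-membered non-aromatic ring with 2 hetero atoms), on a saturated chain carbon bound to a sulfonyl sulfur, and it produced a number 19.7 percentage points higher from compound 3 to compound 1 (beyond the scatter). The same change is made from compound 2 to compound 4: a group of 5 heavy atoms (3 carbon, 1 nitrogen, 1 oxygen; one five-membered non-aromatic ring with 2 hetero atoms) in place of a group of 5 heavy atoms (3 carbon, 1 nitrogen, 1 sulfur; one five-membered non-aromatic ring with 2 hetero atoms), on a saturated chain carbon bound to a sulfonyl sulfur. Within the data shown here, a step of similar size is expected on the second core because a number 19.7 percentage points higher from compound 3 to compound 1 (beyond the scatter) is the only measured instance of this change, but it starts from compound 2, which is "not active" (no number reported). Compound 4 is therefore expected to show only a weak effect in this assay, estimated at 15%. Its expected range runs from 0% to 32%, and a report without a number remains quite possible.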

Compound 4, a percentage reported as activity, at one concentration (the size of the read-out at that concentration, not a potency): 53.9%
Compound 4: middle estimate off by 38.9 percentage points, on the low side; the measured number lies above the stated range.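

Among these compounds, compound 2 has no number, so no step to compound 4 can be read. The compounds shown leave open how large this ring change is on their shared core. Nothing shown explains the result of compound 4.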